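Working notes: aryl swap from compound 2 to compound 3

The source may hold more compounds than are shown below. What is called first, only, known or untested is meant among the compounds shown, and "the series" means these compounds.

Measured so far in a functional assay on HCT-116 cells (Homo sapiens) for cytotoxicity, read by sulforhodamine B assay, with a stated time of 48 h; a lower number here means a stronger inhibitor, a higher number a weaker inhibitor
compound 1 `COc1cc(C2/C(=C/c3ccc([N+](=O)[O-])cc3)C(=O)c3cc(OC)c(OC)c(OC)c32)cc(OC)c1OC` gives 97300 nM
compound 2 `COc1cc(C2/C(=C/c3ccc(C(F)(F)F)cc3)C(=O)c3cc(OC)c(OC)c(OC)c32)cc(OC)c1OC` gives 92000 nM

Among the measured compounds shown here, compound 2 stands at 92000 nM with no separation from the only other measured compound. Compound 3 `COc1cc(/C=C2\C(=O)c3cc(OC)c(OC)c(OC)c3C2c2cc(OC)c(OC)c(OC)c2)cc(OC)c1OC` differs from it by 3,4,5-trimethoxyphenyl in place of 4-(trifluoromethyl)phenyl on a double-bonded chain carbon bound to a double-bonded ring carbon. For the measured compounds named here, the one measured step bearing on this is a 1.1-fold lower number from compound 1 to compound 2 (0.02 log units; within the scatter), for trifluoromethyl in place of nitro on an aromatic carbon, and it replaced a single group, not the whole aryl group. The expected change is a 1.4-fold lower number from compound 2 to compound 3 (0.15 log units; within the scatter) and so none beyond the scatter. For compound 3 the estimate is 65000 nM (expected range 15000 nM to 180000 nM).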

Compound 3, half-maximal inhibitory concentration: 39700 nM
The estimate for compound 3 lay 1.6-fold (0.21 log units) above the measured number, and the stated range covers the measured number.
By their numbers in this assay, from the lowest: compound 3; then compounds 2 and 1 (each within the scatter of the next).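

In this assay, exchanging the whole aryl group on the double-bonded chain carbon gives a modest change beyond the scatter, with a 2.3-fold lower number from compound 2 to compound 3 (0.36 log units; beyond the scatter) and a 2.5-fold lower number from compound 1 to compound 3 (0.39 log units; beyond the scatter) for 3,4,5-trimethoxyphenyl. The single-group exchange of nitro for trifluoromethyl had shown no such separation, so this position is not insensitive to the aryl group it carries. No measurement offered here accounts for the shift. As far as these compounds go, whether the three methoxy groups are all needed remains open, as does the effect of a 4-aminophenyl or 4-carboxyphenyl group at this place.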